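The compounds below may be only part of what the source reports. "The series", "measured", "known", "first", "only" and "open" are said of these compounds alone.

Compound 1 `CCCOC(=O)c1ccc(S(N)(=O)=O)cc1` and compound 2 `CCCCOC(=O)c1ccc(S(N)(=O)=O)cc1` share one core. In a physicochemical assay for lipophilicity (a lower number here means a more polar compound, a higher number a more lipophilic compound), compound 1 gives 1.75, and compound 2 gives 2.34. The change methyl in place of hydrogen on a saturated chain carbon, three bonds along the chain from an oxygen next to a carbonyl group produced a number 0.59 log units higher from compound 1 to compound 2 (beyond the scatter). Compound 3 `CCCCOC(=O)c1ccccc1S(N)(=O)=O` has another core; the difference between the two cores is not broken down here. In this assay compound 3 gives 2.01, within the scatter of compound 1 and lower than compound 2 beyond the scatter.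

Compound 4 `CCCCCOC(=O)c1ccccc1S(N)(=O)=O` awaits measurement. It differs from compound 3 by methyl in place of hydrogen on a saturated chain carbon, four bonds along the chain from an oxygen next to a carbonyl group, the same kind of change as that from compound 1 to compound 2, though here the methyl sits four bonds along the chain from an oxygen next to a carbonyl group rather than three. Since the same kind of change produced a number 0.59 log units higher from compound 1 to compound 2 (beyond the scatter), the expected step is a number 0.54 log units higher from compound 3 to compound 4 (beyond the scatter). Compound 4 is thus estimated at 2.55, between 2.25 and 2.85.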

Compound 4, partition coefficient: 2.55
Beside the measured number, compound 4's estimate shows no gap at the digits printed, and the stated range covers the measured number.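

In this assay the change gives a number 0.54 log units higher from compound 3 to compound 4 (beyond the scatter) on the core of compound 3, and the same kind of change gave a number 0.59 log units higher from compound 1 to compound 2 (beyond the scatter) on the core of compound 1, so both steps are modest and the change carried across these two cores. This rests on a single pair per core, with the methyl four bonds along the chain from an oxygen next to a carbonyl group in one pair and three bonds along in the other, so core and place are not separated and no general rule follows. Nothing given here explains the step on either core.

As far as these compounds go, whether a longer chain would extend the step on either core remains open. So does the outcome of placing an amine on the chain.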